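Ethoxyphenyl to Nitrophenyl on the Amide Carbonyl

The compounds below may be only part of what the source reports. "The series", "measured", "known", "first", "only" and "open" are said of these compounds alone.

Compound 1, `Cc1ccc(C(=O)Nc2cccc(NC(=O)COc3ccc4c(=O)ccoc4c3)c2)cc1`: 183 nM
Compound 2, `CCOc1ccc(C(=O)Nc2cccc(NC(=O)COc3ccc4c(=O)ccoc4c3)c2)cc1`: 17 nM

Within the data shown here, in an assay on isolated protein for inhibition of Rho-associated protein kinase 1 (Homo sapiens), read by scintillation counting, radiometric assay and 33P incorporation, with a stated time of 40 min, in the presence of a further agent that is not named here (a higher number here means a weaker inhibitor, a lower number a stronger inhibitor), compound 2 gives the lowest of the two numbers; the single measured step, an 11-fold lower number from compound 1 to compound 2 (1.03 log units; beyond the scatter), is large and concerns the group on this same carbonyl. Compound 3, `O=C(COc1ccc2c(=O)ccoc2c1)Nc1cccc(NC(=O)c2cccc([N+](=O)[O-])c2)c1`, differs from compound 2 by 3-nitrophenyl in place of 4-ethoxyphenyl on a carbonyl carbon. That one step shows the number moves strongly with the group at this place, yet it says nothing about a nitrophenyl, so the direction is uncertain. Compound 3 is expected to show a 3.5-fold higher number from compound 2 to compound 3 (0.55 log units; beyond the scatter). In this assay compound 3 is estimated at 60 nM, between 15 nM and 250 nM.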

Compound 3, half-maximal inhibitory concentration: 528 nM
For compound 3 the middle estimate is 8.8-fold (0.94 log units) below the measured one; the measured number lies above the stated range.
By their numbers in this assay, from the lowest: compound 2; then compound 1; then compound 3.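

In this assay the group on this carbonyl can raise the number as well as lower it: a 31-fold higher number from compound 2 to compound 3 (1.49 log units; beyond the scatter) is large, and a 2.9-fold higher number from compound 1 to compound 3 (0.46 log units; beyond the scatter) is modest. Compound 3 is therefore the weakest inhibitor of the three, although 4-ethoxyphenyl and 3-nitrophenyl both count 9 heavy atoms. Nothing given here explains this order. The compounds shown do not separate the nitro group from its place on the ring, as 4-nitrophenyl would. On these data alone, how an amine or a longer alkoxy chain such as propoxy would read here also remains open.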